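Lengthening the chain on the shared core

This account rests on a few compounds, and the source may have more. Where it says the series, first, only, none or still open, it means among the compounds named here.

Measured in a functional assay on MCF7 cells (Homo sapiens) for antiproliferative activity, with a stated time of 5 days (a higher number here means a weaker inhibitor, a lower number a stronger inhibitor), so far
compound 1 `COc1ccc(-c2[nH]c3cc(OC)ccc3c2C=O)cc1` gives 160 nM
compound 2 `COc1ccc(-c2[nH]c3ccc(C)cc3c2C=O)cc1` gives 140 nM
compound 3 `CCCCc1ccc2[nH]c(-c3ccc(OC)cc3)c(C=O)c2c1` gives 22 nM

Compound 3 has the lowest number of the three, beyond the scatter from both compound 1 and compound 2. Compound 4 `CCCCCc1ccc2[nH]c(-c3ccc(OC)cc3)c(C=O)c2c1` is still unmeasured and differs from compound 3 by methyl in place of hydrogen on a saturated chain carbon, four bonds along the chain from an aromatic carbon alone. For the measured compounds named here, the one measured step bearing on this is a 6.4-fold lower number from compound 2 to compound 3 (0.80 log units; beyond the scatter) and it came with propyl, a larger addition than methyl, so in this assay a smaller step is expected, probably none beyond the scatter. The expected change is a 1.1-fold lower number from compound 3 to compound 4 (0.04 log units; within the scatter) on this estimate. The estimate for compound 4 is 20 nM with an expected range from 8 nM to 55 nM in this read-out.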

Compound 4, half-maximal inhibitory concentration: 20 nM
Compound 4: the middle estimate sits on the measured number at the digits printed; the measured number falls inside the stated range.
By their numbers in this assay, from the lowest: compounds 4 and 3 (each within the scatter of the next); then compounds 2 and 1 (each within the scatter of the next).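

In this assay the methyl added four bonds along the chain from an aromatic carbon gives a 1.1-fold lower number from compound 3 to compound 4 (0.04 log units; within the scatter) and so no readable change. The longer chain keeps its gain, at a 7.0-fold lower number from compound 2 to compound 4 (0.85 log units; beyond the scatter) overall, so the earlier gain survives this extension without growing. Nothing available explains this flat last step.

On these data alone, whether a still longer chain would hold this level stays open, as does the effect of a branched chain. So does what an amine or a carboxylic acid in place of the chain would do.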